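Naphthoquinone side-chain variants in a HeLa cytotoxicity assay

The compounds below may be only part of what the source reports. "The series", "measured", "known", "first", "only" and "open" are said of these compounds alone.

The series shares one core, carried here by compound 3 `CCCC(C)(O)CC(=O)O[C@H](CC=C(C)C)C1=CC(=O)c2c(O)ccc(O)c2C1=O`, which in a functional assay on HeLa cells (Homo sapiens) for cytotoxicity, read by MTT assay (a higher number here means a weaker inhibitor, a lower number a stronger inhibitor), gives 72000 nM, the highest of the two numbers recorded. Compound 2 `CC[C@](C)(O)CC(=O)O[C@H](CC=C(C)C)C1=CC(=O)c2c(O)ccc(O)c2C1=O` gives 30200 nM in this assay. Compound 1 `CC(C)=CC[C@@H](OC(=O)C1CCCCO1)C1=CC(=O)c2c(O)ccc(O)c2C1=O` reaches only a limit of the assay, > 100000 nM, and the step of an at least 1.3-fold lower number from compound 1 to compound 3 (0.14 log units; that floor lies within the scatter) therefore rests on that limit (the limit of > 100000 nM in this assay, at which 1 of the 3 values shown sits). The step of an at least 3.3-fold lower number from compound 1 to compound 2 (0.51 log units; beyond the scatter) also rests on it. Within the chain series the step of a 2.4-fold higher number from compound 2 to compound 3 (0.38 log units; beyond the scatter) shows that lengthening the chain by one carbon costs potency.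

Compound 4 `CC(C)=CC[C@@H](OCC(C)O)C1=CC(=O)c2c(O)ccc(O)c2C1=O` differs from compound 3 in one place: 2-hydroxypropyl in place of (2-hydroxy-2-methylpentyl)carbonyl on an oxygen on a saturated carbon. Going by the values given here, no measured step swaps the ester for an ether, so the bearing of the three steps above is indirect; they show only that the side chain moves the number by modest amounts. Compound 4 is therefore expected near compound 3, with the step of a 1.2-fold lower number from compound 3 to compound 4 (0.08 log units; within the scatter), and an estimated value of 60000 nM in this assay, between 15000 nM and 200000 nM.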

Compound 4, half-maximal inhibitory concentration: 24700 nM
Compound 4: middle estimate off by 2.4-fold (0.39 log units), on the high side; the measured number falls inside the stated range.
By their numbers in this assay, from the lowest: compounds 4 and 2 (each within the scatter of the next); then compound 3. At a limit, above all of these: compound 1.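

Going by these compounds alone, compound 4 is the first compound here without a carbonyl in the group on this oxygen, and the ether keeps a measurable number in this assay, so that carbonyl is not required for one. Against the longer ester the change gives a 2.9-fold lower number from compound 3 to compound 4 (0.46 log units; beyond the scatter), while against the shorter ester it gives a 1.2-fold lower number from compound 2 to compound 4 (0.09 log units; within the scatter), which leaves the ether level with compound 2 rather than ahead of it. The step of an at least 4.0-fold lower number from compound 1 to compound 4 (0.60 log units; beyond the scatter) is only a floor, set by the limit reached by compound 1: the limit of > 100000 nM in this assay, at which 1 of the 4 values shown sits.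

The change removes the carbonyl and shortens the chain together, so the compounds shown do not separate the two. Going by these compounds, an amine in place of the hydroxyl of the 2-hydroxypropyl group, or a longer chain on the ether oxygen, remains open.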